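This account rests on a few compounds, and the source may have more. Where it says the series, first, only, none or still open, it means among the compounds named here.

Compound 1 `COc1ncnc2c1c(-c1cc3ccccc3o1)cn2[C@@H]1O[C@H](CO)[C@@H](O)[C@H]1O` gives 20900 nM
Compound 2 `CSc1ncnc2c1c(-c1ccoc1)cn2[C@@H]1O[C@H](CO)[C@@H](O)[C@H]1O` gives 60 nM

Of the compounds shown here, two have been measured so far. In a functional assay on K562 cells (Homo sapiens), read by MTT assay, with a stated time of 72 h (on this read-out higher numbers stand for weaker inhibition and lower numbers for stronger inhibition), compound 2 gives 60 nM and holds the lower of the two numbers. Compound 1 gives 20900 nM and stands well beyond the usual scatter on the side of weaker inhibition. These two compounds differ in more than one place, so their values alone do not isolate the effect of any one group.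

The next compound, compound 3 `C#Cc1cn([C@@H]2O[C@H](CO)[C@@H](O)[C@H]2O)c2ncnc(SC)c12`, keeps the shared core and sugar of compound 2 but has ethynyl in place of furan-3-yl on an aromatic carbon in the five-membered aromatic ring with 1 nitrogen. Going by the values given here, no measured pair shows this exchange, so the expectation remains tentative. A modest move toward weaker inhibition in this assay is expected, slightly beyond the scatter, and the estimated change is a 3.3-fold higher number from compound 2 to compound 3 (0.52 log units; beyond the scatter) on this measure. For compound 3 the estimated value is 200 nM with an expected range from 30 nM to 2000 nM in this cell test.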

Compound 3, half-maximal inhibitory concentration: 30 nM
Compound 3: middle estimate off by 6.7-fold (0.82 log units), on the high side; low and high end bracket the measured number.
By their numbers in this assay, from the lowest: compounds 3 and 2 (each within the scatter of the next); then compound 1.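

In this assay, the exchange of furan-3-yl for ethynyl on an aromatic carbon of the five-membered aromatic ring with 1 nitrogen reads as a 2.0-fold lower number from compound 2 to compound 3 (0.30 log units; within the scatter) and so does not separate the two compounds on this read-out. This is the first exchange shown at this position that can be read on its own: ethynyl, with 2 heavy atoms, no ring and no hydrogen-bond acceptor, stands here in place of furan-3-yl, with 5 heavy atoms, a ring and 1 hydrogen-bond acceptor, and the numbers stay within the scatter of each other, so for this pair neither the furan ring nor its oxygen is required for a value of this size. No evidence at hand accounts for this result.

Compound 1 differs from compound 2 and compound 3 in more than one place, so the reading of compound 1 at 20900 nM cannot be assigned to any single group. Still open, on these data alone, is how an amine, a carboxylic acid or a longer chain ending in an ethynyl group would read on this same aromatic carbon.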